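Swapping Cyclopentyl for a Pyrazolylethyl Chain

The source may report more compounds than this note shows. Statements on the series, on what has been measured and on what is new or still open speak of the compounds shown alone.

Compound 1, `Cc1nn(-c2ncnc3nc[nH]c23)c2c1C(OC1CCCC1)CC(=O)N2`, gives 62 nM in a functional assay on HEK293 cells for agonist activity at G-protein coupled receptor 39 (Homo sapiens), read by scintillation proximity assay and inositol phosphate accumulation, with a stated time of 75 min (on this read-out higher numbers stand for an effect only at larger amounts of compound and lower numbers for an effect already at smaller amounts), the lowest of the three numbers shown. Compound 2, `Cc1nn(-c2ncnc3nc[nH]c23)c2c1C(OCc1ccc(F)cc1)CC(=O)N2`, gives 126 nM, and compound 3, `Cc1nn(-c2ncnc3nc[nH]c23)c2c1C(NC(=O)c1ccccc1)CC(=O)N2`, gives 158 nM. The step of a 2.0-fold higher number from compound 1 to compound 2 (0.31 log units; beyond the scatter) and the step of a 2.5-fold higher number from compound 1 to compound 3 (0.41 log units; beyond the scatter) both show that replacing the cyclopentyl, or the whole cyclopentyloxy, moves the number modestly upward. Compound 4, `Cc1nn(-c2ncnc3nc[nH]c23)c2c1C(OCCn1cccn1)CC(=O)N2`, differs from compound 1 by 2-(1H-pyrazol-1-yl)ethyl in place of cyclopentyl on an oxygen on a saturated carbon. The most comparable step is a 2.0-fold higher number from compound 1 to compound 2 (0.31 log units; beyond the scatter), where another group replaced cyclopentyl on an oxygen on a saturated carbon, so a similar modest rise is expected here. Compound 4 is therefore estimated at 150 nM, with a likely range from 60 nM to 400 nM, which would mean a 2.4-fold higher number from compound 1 to compound 4 (0.38 log units; beyond the scatter).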

Compound 4, half-maximal effective concentration: 2270 nM
Estimate against measurement, compound 4: 15-fold (1.18 log units) below; the measured number lies above the stated range.
By their numbers in this assay, from the lowest: compound 1; then compounds 2 and 3 (each within the scatter of the next); then compound 4.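

Compared with the modest steps among the earlier compounds, this position proves far less tolerant: 2-(1H-pyrazol-1-yl)ethyl in place of cyclopentyl gives a large rise (a 37-fold higher number from compound 1 to compound 4 (1.56 log units; beyond the scatter)). The other two comparisons are also large (an 18-fold higher number from compound 2 to compound 4 (1.26 log units; beyond the scatter); a 14-fold higher number from compound 3 to compound 4 (1.16 log units; beyond the scatter)), so a change at this site can move the number strongly. No supporting data explain this rise.

From the compounds shown here alone, whether the pyrazolyl ring or the ethyl chain drives the change remains open, and a 2-phenylethyl group would help separate the two. How a chain ending in an amine would behave is also unresolved.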